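A few compounds are considered here, and "the series" means these few. Any claim that something is new, unique, unknown or untested is made for them only; others in the source may bear on it.

Compound 3 `COc1ccc(/C=C/C(=O)c2c(O)cc(O)cc2OC)cc1` gives 47700 nM in a functional assay on HeLa cells (Homo sapiens) for inhibition, read by MTT assay, with a stated time of 72 h (a lower number here means a stronger inhibitor, a higher number a weaker inhibitor), and compound 2 `COc1cc(O)c(CC=C(C)C)c(O)c1C(=O)/C=C/c1ccc([N+](=O)[O-])cc1` gives 29700 nM, so the two values lie within the scatter of each other. Compound 1 `COc1ccc(/C=C/C(=O)c2c(OC)cc(O)c(CC=C(C)C)c2O)cc1` gives > 50000 nM, which is a limit of the assay and not a number.

The next step leads to compound 4 `COc1cc(O)cc(O)c1C(=O)/C=C/c1ccc([N+](=O)[O-])cc1`, with nitro in place of methoxy on an aromatic carbon, para to a large group: nitro in place of methoxy on an aromatic carbon. The same exchange, made on the core that still carries 3-methylbut-2-en-1-yl, gives an at least 1.6-fold lower number from compound 1 to compound 2 (0.22 log units; that floor lies within the scatter). Hydrogen in place of 3-methylbut-2-en-1-yl gives an at least 1.0-fold lower number from compound 1 to compound 3 (0.02 log units; that floor lies within the scatter). Both steps are floors only, and neither shows a change beyond the scatter.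

A small move to a lower number in this assay is therefore expected, resting on the exchange seen in an at least 1.6-fold lower number from compound 1 to compound 2 (0.22 log units; that floor lies within the scatter), but nothing beyond the scatter is anticipated. The estimated step is a 1.6-fold lower number from compound 3 to compound 4 (0.20 log units; within the scatter). Compound 4 is expected at 30000 nM, with an estimated range of 13000 nM to 60000 nM.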

Compound 4, half-maximal inhibitory concentration: > 50000 nM
Compound 4 ended at the assay's limit; the forecaster's own chance of this, stated with the estimate: 20%; middle value at least 1.6-fold (0.22 log units) away from the limit.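

On the core without 3-methylbut-2-en-1-yl, nitro in place of methoxy gives an at least 1.0-fold higher number from compound 3 to compound 4 (0.02 log units; that floor lies within the scatter) in this assay, and on the nitro core, hydrogen in place of 3-methylbut-2-en-1-yl gives an at least 1.6-fold higher number from compound 2 to compound 4 (0.22 log units; that floor lies within the scatter); both are floors only. Compound 4 is a limit of the assay and not a number, so the nitro exchange has now been read on two cores without a change beyond the scatter on either: the same change on two cores in this assay, an at least 1.6-fold lower number (0.22 log units; that floor lies within the scatter) from compound 1 to compound 2 and an at least 1.0-fold higher number (0.02 log units; that floor lies within the scatter) from compound 3 to compound 4; the limit leaves it open whether they differ The exchange of 3-methylbut-2-en-1-yl for hydrogen, also read on two cores, stands the same way: the same change on two cores in this assay, an at least 1.0-fold lower number (0.02 log units; that floor lies within the scatter) from compound 1 to compound 3 and an at least 1.6-fold higher number (0.22 log units; that floor lies within the scatter) from compound 2 to compound 4; the limit leaves it open whether they differ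

Going by these compounds, the true size of either exchange stays open, since some of the values stop at the limit: the limit of > 50000 nM in this assay, at which 2 of the 4 values shown sit. Whether an amine or a carboxylic acid at this position, para to a large group, would give a number clear of that limit also stays open.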